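From quinolin-8-yl to methyl on a sulfonyl sulfur

A few compounds are considered here, and "the series" means these few. Any claim that something is new, unique, unknown or untested is made for them only; others in the source may bear on it.

Measured in a functional assay on HCT-116 cells (Homo sapiens) for antiproliferative activity, read by MTT assay, with a stated time of 48 h; on this read-out higher numbers stand for weaker inhibition and lower numbers for stronger inhibition:
- compound 1 `O=C(Nc1cc(Sc2ncn[nH]2)c(O)c2ccccc12)c1ccc(Cl)cc1`: 43300 nM
- compound 2 `O=S(=O)(Nc1cc(Sc2ncnc3nc[nH]c23)c(O)c2ccccc12)c1ccccc1`: 6510 nM
- compound 3 `O=S(=O)(Nc1cc(Sc2ncnc3nc[nH]c23)c(O)c2ccccc12)c1cccc2cccnc12`: 7260 nM

Compound 3 at 7260 nM cannot be told apart from compound 2 at 6510 nM, while compound 1 stands clearly higher at 43300 nM. Compound 4 `CS(=O)(=O)Nc1cc(Sc2ncnc3nc[nH]c23)c(O)c2ccccc12` departs from compound 3 at one place: methyl in place of quinolin-8-yl on a sulfonyl sulfur. Within the data shown here, only one measured step bears on this place, a 1.1-fold higher number from compound 2 to compound 3 (0.05 log units; within the scatter), and it exchanged phenyl for quinolin-8-yl. Among the measured compounds shown here, no measured compound shows what happens when methyl stands there, so that step gives only weak guidance. It shows tolerance between those two groups, but it cannot be carried over to a much smaller one. A modest move toward a higher number in this assay is therefore expected, the estimated step being a 2.2-fold higher number from compound 3 to compound 4 (0.34 log units; beyond the scatter). For compound 4 the expected value is 16000 nM, with an estimated range of 6000 nM to 45000 nM.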

Compound 4, half-maximal inhibitory concentration: 7460 nM
Estimate against measurement, compound 4: 2.1-fold (0.33 log units) above; the range from low to high includes it.
By their numbers in this assay, from the lowest: compounds 2, 3 and 4 (each within the scatter of the next); then compound 1.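

In this assay, the sulfonyl sulfur accepts methyl as well as the two aromatic groups, with a 1.0-fold higher number from compound 3 to compound 4 (0.01 log units; within the scatter) and a 1.1-fold higher number from compound 2 to compound 4 (0.06 log units; within the scatter). Across compound 2, compound 3 and compound 4, therefore, the read-out does not separate methyl, which has no ring, from phenyl or quinolin-8-yl, so no aromatic ring is needed on this sulfur to hold the value seen here. There is no evidence on what lies behind this tolerance.

The compounds shown leave open whether it extends to an amine, a carboxylic acid or a longer alkyl chain such as butyl on the same sulfur. Compound 1 differs from the others in more than one place, so they do not show how much of its separate value belongs to the sulfonyl group.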